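Replacing Trimethoxyphenyl with Bromophenyl in a Cytotoxicity Series

The compounds below may be only part of what the source reports. "The series", "measured", "known", "first", "only" and "open" are said of these compounds alone.

Compound 1 `COc1cc(-c2nc(SCc3cn(CC(=O)NC(=O)Nc4ccccn4)nn3)nc(Nc3ccc(C)cc3)c2C#N)cc(OC)c1OC` gives in an ADME assay on GES1 cells (Homo sapiens) for inhibition, read by MTT assay, with a stated time of 72 h (on this read-out higher numbers stand for weaker inhibition and lower numbers for stronger inhibition), a limit of > 64000 nM, not a number.
Compound 2 `COc1cc(-c2nc(SCc3cn(CC(=O)NC(=O)Nc4ccccn4)nn3)nc(Nc3cccc(C(F)(F)F)c3)c2C#N)cc(OC)c1OC` gives in this assay a limit of > 64000 nM, not a number.
Compound 3 `Cc1ccc(-c2nc(SCc3cn(CC(=O)NC(=O)Nc4ccccn4)nn3)nc(Nc3ccc(C(C)C)cc3)c2C#N)cc1` gives in this assay a limit of > 64000 nM, not a number.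

Compound 2 therefore stands at the limit of this assay, and so do the two other measured compounds (the limit of > 64000 nM in this assay, at which 3 of the 3 values shown sit). Within the data shown here, the single measured step between compounds that differ in one place, a step that the two limits leave unreadable from compound 1 to compound 2, is unreadable, since both of its ends are limits; it concerns the amino-linked aryl group and not the position changed here.

Compound 4 `N#Cc1c(Nc2cccc(C(F)(F)F)c2)nc(SCc2cn(CC(=O)NC(=O)Nc3ccccn3)nn2)nc1-c1ccc(Br)cc1` differs from compound 2 by 4-bromophenyl in place of 3,4,5-trimethoxyphenyl on an aromatic carbon. Among the measured compounds shown here, no measured step touches this position, so nothing about the size of this step can be read from the data. What the data do show is that every measured compound, whatever its aryl groups, sits at the limit (the limit of > 64000 nM in this assay, at which 3 of the 3 values shown sit). On that basis the step from compound 2 to compound 4 is expected to be a number no higher from compound 2 to compound 4 (the limit leaves the size open), that is, no change beyond the scatter. Compound 4 is accordingly estimated at 64000 nM, within a range from 30000 nM to 200000 nM, and it is expected that this assay again reports only a limit rather than a number.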

Compound 4, half-maximal inhibitory concentration: 38700 nM
For compound 4 the middle estimate is 1.7-fold (0.22 log units) above the measured one; low and high end bracket the measured number.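

In this assay, 4-bromophenyl in place of 3,4,5-trimethoxyphenyl on an aromatic carbon gives an at least 1.6-fold lower number from compound 2 to compound 4 (0.21 log units; that floor lies within the scatter). This is the first sign that this position can bear on the read-out at all, since compound 4 is the only one of the four compounds shown that gives a number, 38700 nM, while the earlier compounds offered no number to compare. The true size of the change remains unknown, however, and the evidence for it is thin, since compound 2 gives only a limit and the other two earlier compounds sit with it: the limit of > 64000 nM in this assay, at which 3 of the 4 values shown sit.

The compounds shown leave open whether the step follows from the bromine that enters or from the three methoxy groups that leave, a question that an unsubstituted phenyl or a 4-methoxyphenyl at this position would help to separate. They also leave open whether 4-bromophenyl gives a number with other groups on the amino nitrogen, such as 4-methylphenyl, and how a 4-chlorophenyl or a 4-aminophenyl would read here.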